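Extending the Acid Chain in a Vitamin D Receptor Antagonist

The source may hold more compounds than are shown below. What is called first, only, known or untested is meant among the compounds shown, and "the series" means these compounds.

Measured in an assay on cells for antagonist activity at vitamin D3 receptor (Homo sapiens), read by a luciferase reporter; a lower number here means a stronger inhibitor, a higher number a weaker inhibitor:
Compound 1, `COC(=O)CCc1ccc(OCc2oc(-c3ccccc3OC)nc2C)cc1`, gives 13600 nM.
Compound 2, `COc1ccccc1-c1nc(C)c(COc2ccc(C(=O)O)cc2)o1`, reaches only the limit > 80000 nM.
Compound 3, `COc1cccc(-c2nc(C)c(COc3ccc(C(=O)O)cc3)o2)c1`, reaches only the limit > 80000 nM.

Compound 2 stands at the limit of this assay, so no number is known for it. Two of the three values shown sit there (the limit of > 80000 nM in this assay, at which 2 of the 3 values shown sit). Compound 4, `COc1ccccc1-c1nc(C)c(COc2ccc(CCC(=O)O)cc2)o1`, differs from compound 2 by 2-carboxyethyl in place of carboxy on an aromatic carbon. Among the measured compounds shown here, the one step that bears on this change is an at least 5.8-fold higher number from compound 1 to compound 2 (0.76 log units; beyond the scatter), in which shortening and freeing the acid weakened the compound; compound 4 carries the chain of compound 1 but as a free acid. The step that the two limits leave unreadable from compound 2 to compound 3 gives no guidance. A return toward measurable inhibition is expected. Compound 4 is estimated at 40000 nM, between 12000 nM and 120000 nM. The estimated step is an at least 2.0-fold lower number from compound 2 to compound 4 (0.30 log units; that floor lies within the scatter).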

Compound 4, half-maximal inhibitory concentration: > 100000 nM
Compound 4 ended at the assay's limit; the forecaster's own chance of this, stated with the estimate: 40%; middle value at least 2.5-fold (0.39 log units) away from the limit.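

At this position, on an aromatic carbon para to a large group, the 2-carboxyethyl chain as a free acid brings no readable inhibition back in this assay. With the chain kept, hydrogen in place of the ester methyl alone gives an at least 7.3-fold higher number from compound 1 to compound 4 (0.86 log units; beyond the scatter), so among these compounds only the ester compound 1 has a measured number. Compound 4 stands at a limit of the assay, and its step from compound 2 cannot be read: the limit of > 100000 nM in this assay, at which 1 of the 4 values shown sits.

On these data alone, whether compound 2 and compound 4 differ at all stays open. So does whether an amide or a longer chain at this position would give a measurable value.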